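The source may report more compounds than this note shows. Statements on the series, on what has been measured and on what is new or still open speak of the compounds shown alone.

Measured in an ADME assay on HFF cells (Homo sapiens) for cytotoxicity, read by neutral red uptake (on this read-out lower numbers stand for higher toxicity in this test and higher numbers for lower toxicity in this test), all values being limits of the assay:
compound 1 `Nc1nc2c(ncn2/C=C2\C[C@@H]2[C@H](O)CO)c(=O)[nH]1`: > 300000 nM
compound 2 `Nc1ncnc2c1ncn2/C=C1/C[C@@H]1[C@H](O)CO`: > 300000 nM
compound 3 `Nc1ncnc2c1ncn2/C=C1\C[C@@H]1[C@@H](O)CO`: > 300000 nM

Compound 1 gives > 300000 nM, which is a limit and not a number. For the measured compounds named here, the series so far offers no rank order: the limit of > 300000 nM in this assay, at which 3 of the 3 values shown sit.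

The next compound to read is compound 4 `Nc1nc2c(ncn2/C=C2\C[C@H]2[C@@H](O)CO)c(=O)[nH]1`. Its change from compound 1 is this: the two compounds have the same atoms and bonds and differ only in configuration as drawn: 2 of 3 stereo elements differ; a stereocentre at a saturated ring carbon is drawn S in compound 1 and R in compound 4; a stereocentre at a saturated chain carbon is drawn S in compound 1 and R in compound 4. No atom leaves or enters.

Going by the values given here, one measured step bears on this change: a step that the two limits leave unreadable from compound 2 to compound 3. It is likewise a matter of configuration alone, as shown by the fact that compounds 2 and 3 differ only in the configuration as drawn. It also involves a stereocentre at a saturated chain carbon drawn S and then R, though its second difference is a double bond drawn Z and then E, not a ring stereocentre. Its size cannot be read, so it offers no evidence of a real change in this assay, and none of its absence.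

The expectation therefore rests mainly on compound 1 , whose value is the limit > 300000 nM. The expected step of a number no higher from compound 1 to compound 4 (the limit leaves the size open) is none beyond the usual scatter, with no direction favoured. Compound 4 is expected at 300000 nM, with an estimated range of 120000 nM to 600000 nM, and the assay will most likely report only a limit.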

Compound 4, half-maximal cytotoxic concentration: 298000 nM
For compound 4 the middle estimate is 1.0-fold (0.00 log units) above the measured one; low and high end bracket the measured number.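

In this assay, for the compounds shown here, compound 4 gives 298000 nM, the first value that is a number and not a limit. Compound 1 gives > 300000 nM, which is a limit of the assay. This pair shows a number no higher from compound 1 to compound 4 (the limit leaves the size open) and so the size of the step cannot be read, any more than the step between compound 2 and compound 3, and the change at the saturated ring carbon and the saturated chain carbon has no measured size, although the comparison itself is clean: the fact that compounds 1 and 4 differ only in the configuration as drawn. A single number does not yet give the series a rank order: the limit of > 300000 nM in this assay, at which 3 of the 4 values shown sit.

The compounds shown leave open what each of the two stereocentres does on its own, since they change together within this pair, and whether the double bond drawn Z or E matters on the core of compound 1. Also open, from the compounds shown here alone, is how a compound carrying an amine or a carboxylic acid in place of the hydroxyl groups would read in this assay.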